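Shortening the unsaturated ester chain on the oxane core

The source may hold more compounds than are shown below. What is called first, only, known or untested is meant among the compounds shown, and "the series" means these compounds.

Compound 2 `COC(=O)/C=C/C[C@H]1OCCC[C@@H]1O[Si](C)(C)C(C)(C)C` is measured in a functional assay on MCF7S cells (Homo sapiens) (on this read-out higher numbers stand for weaker inhibition of growth and lower numbers for stronger inhibition of growth), where compound 2 gives 18000 nM. Among the entries with a reported number, compound 2 holds the lowest figure, and its nearest neighbour is compound 1 `CC(C)(C)[Si](C)(C)O[C@H]1CCCO[C@@H]1CC=O`: in this assay compound 1 gives 21000 nM, and the step of a 1.2-fold lower number from compound 1 to compound 2 (0.07 log units; within the scatter) lies within the scatter, so the two compounds cannot be told apart on these numbers. A further entry, compound 3 `COC(=O)/C=C/C[C@H]1OCCC[C@@H]1OC(=O)c1ccccc1`, is reported in this assay as "not active" (no number reported), with no number given for compound 3.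

Compound 4 `COC(=O)/C=C/[C@H]1OCCC[C@@H]1O[Si](C)(C)C(C)(C)C` has not been measured. Its difference from compound 2 is 2-(methoxycarbonyl)ethenyl in place of 3-(methoxycarbonyl)prop-2-en-1-yl on a saturated ring carbon. Among the measured compounds shown here, only one measured step touches the same side chain, a 1.2-fold lower number from compound 1 to compound 2 (0.07 log units; within the scatter), in which 2-(methoxycarbonyl)ethenyl replaced formyl on the chain without moving the read-out beyond the scatter. For the measured compounds named here, no measured pair removes a chain carbon in this way, so the expectation rests on the flat picture the two numbers give. Compound 4 is therefore expected to give 20000 nM in this assay, with a plausible range from 7000 nM to 60000 nM. The estimated step of a 1.1-fold higher number from compound 2 to compound 4 (0.05 log units; within the scatter) is expected to stay within the scatter, in no clear direction.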

Compound 4, concentration for 50% growth inhibition: 24000 nM
Compound 4: middle estimate off by 1.2-fold (0.08 log units), on the low side, and the stated range covers the measured number.
By their numbers in this assay, from the lowest: compounds 2, 1 and 4 (each within the scatter of the next).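

In this assay, among the compounds shown here, the swap on the saturated ring carbon of 3-(methoxycarbonyl)prop-2-en-1-yl for the shorter 2-(methoxycarbonyl)ethenyl gives a 1.3-fold higher number from compound 2 to compound 4 (0.12 log units; within the scatter), the first measured change in the length of the unsaturated ester chain itself. The step from formylmethyl to the same 2-(methoxycarbonyl)ethenyl gives a 1.1-fold higher number from compound 1 to compound 4 (0.06 log units; within the scatter), so the three side chains now measured at this place, next to the ring oxygen, cannot be told apart on these numbers while the rest of the core stays the same. No separate measurement bears on this result, and the numbers alone do not explain why the read-out stays flat.

The compounds shown leave open whether the same flat picture would hold for a carboxylic acid in place of the methyl ester, for an amine on the chain, or for a chain longer than 3-(methoxycarbonyl)prop-2-en-1-yl. They also leave open how the shorter 2-(methoxycarbonyl)ethenyl chain would read out on a core carrying the benzoate ester of compound 3, which has no number to compare.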